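The source may report more compounds than this note shows. Statements on the series, on what has been measured and on what is new or still open speak of the compounds shown alone.

Compound 1 `COc1cc(/C=C/C(=O)c2cccc(NC(=O)c3ccc(Cl)cc3Cl)c2)ccc1O`: 34.4 ug/mL
Compound 2 `COc1cc(/C=C/C(=O)c2cccc(NC(=O)c3ccc(Cl)c(Cl)c3)c2)ccc1O`: 25.3 ug/mL
Compound 3 `COc1cc(/C=C/C(=O)c2cccc(NC(=O)C(C)C)c2)ccc1O`: 5.96 ug/mL

In a functional assay on SiHa cells (Homo sapiens) for inhibition (a lower number here means a stronger inhibitor, a higher number a weaker inhibitor), compound 3 gives 5.96 ug/mL, the lowest of the three numbers, which makes it the strongest inhibitor measured so far. Compound 4 `COC(=O)C(=O)Nc1cccc(C(=O)/C=C/c2ccc(O)c(OC)c2)c1` keeps the shared core and changes one group, with methoxycarbonyl in place of isopropyl on a carbonyl carbon.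

For the measured compounds named here, no measured step involves methoxycarbonyl, so the evidence is only indirect. The nearest guides are the replacements of a dichlorophenyl group by isopropyl at this same place: a 5.8-fold lower number from compound 1 to compound 3 (0.76 log units; beyond the scatter) and a 4.2-fold lower number from compound 2 to compound 3 (0.63 log units; beyond the scatter). Both are modest but real. The swap between the two dichlorophenyl groups, a 1.4-fold lower number from compound 1 to compound 2 (0.13 log units; within the scatter), stays within the scatter. These steps show that this place can move the number, but both involve losing a ring. The change to compound 4 does not, since neither group has one. A step smaller than those two therefore seems likely, and compound 3 already sits lowest, so any movement should lean towards a higher number.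

The expected step is a 1.5-fold higher number from compound 3 to compound 4 (0.18 log units; within the scatter), which would be little or no real change. For compound 4 the estimated value is 9 ug/mL, with an expected range of 3.5 ug/mL to 25 ug/mL.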

Compound 4, half-maximal inhibitory concentration: 7.71 ug/mL
Compound 4: the middle estimate sits 1.2-fold (0.07 log units) above what was measured; measured number inside the range.
By their numbers in this assay, from the lowest: compounds 3 and 4 (each within the scatter of the next); then compounds 2 and 1 (each within the scatter of the next).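

In this assay, a 1.3-fold higher number from compound 3 to compound 4 (0.11 log units; within the scatter) shows that this place on the carbonyl carbon tolerates a clear change in the group: methoxycarbonyl brings oxygen atoms and 2 hydrogen-bond acceptors where isopropyl has none, yet the number does not move beyond the scatter. Methoxycarbonyl also repeats the gap first seen with isopropyl, with a 3.3-fold lower number from compound 2 to compound 4 (0.52 log units; beyond the scatter) and a 4.5-fold lower number from compound 1 to compound 4 (0.65 log units; beyond the scatter), so among these four compounds both groups without a ring give lower numbers than both dichlorophenyl groups, and no compound here goes against that. Nothing measured here explains why the number holds steady between the two ring-free groups or why it rises with the dichlorophenyl groups.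

A plain phenyl group, without chlorine, would help show whether the higher numbers go with the ring itself or with its chlorine atoms. A carboxylic acid in place of methoxycarbonyl, or a longer carbon chain in place of isopropyl, would test how far this tolerance extends among groups without a ring.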